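A few compounds are considered here, and "the series" means these few. Any claim that something is new, unique, unknown or untested is made for them only; others in the source may bear on it.

Measured so far:
Compound 1, `COc1cccc(/C=C/C(=O)c2sc(Nc3ccc(Cl)c(Cl)c3)nc2C)c1`, gives 20100 nM in a functional assay on NCI-H460 cells (Homo sapiens) for cytotoxicity, read by MTT assay; on this read-out lower numbers stand for stronger inhibition and higher numbers for weaker inhibition.
Compound 2, `Cc1ccccc1Nc1nc(C)c(C(=O)/C=C/c2ccc(Cl)cc2)s1`, gives > 25000 nM in this assay.

The value of compound 2 is a limit of the assay, not a number, as shown by the limit of > 25000 nM in this assay, at which 1 of the 2 values shown sits. Compound 3, `COc1cccc(/C=C/C(=O)c2sc(Nc3ccccc3C)nc2C)c1`, differs from compound 2 in one place: 3-methoxyphenyl in place of 4-chlorophenyl on a double-bonded chain carbon bound to a double-bonded chain carbon. Compound 1 carries the same 3-methoxyphenyl group and gives 20100 nM in this assay. Among the compounds with values here, no measured pair differs in a single place, so the size of this change cannot be read from the data. The step of a number no higher from compound 2 to compound 3 (the limit leaves the size open) is expected to stay within the scatter. Compound 3 is therefore expected to give 25000 nM, with a range from 10000 nM to 60000 nM.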

Compound 3, half-maximal inhibitory concentration: > 25000 nM
Compound 3: only a limit was reported; the forecaster's own chance of this, stated with the estimate: 50%; the middle value lies on the limit itself.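

In this assay compound 3 gives > 25000 nM, which is a limit and not a number, so the step that replaces 4-chlorophenyl with 3-methoxyphenyl cannot be read. On a nitrogen on an aromatic ring, 2-methylphenyl in place of 3,4-dichlorophenyl gives an at least 1.2-fold higher number from compound 1 to compound 3 (0.09 log units; that floor lies within the scatter). The series now rests largely on a single limit: the limit of > 25000 nM in this assay, at which 2 of the 3 values shown sit.

From the compounds shown here alone, it remains open whether a phenyl carrying an amine or a carboxylic acid at this chain carbon would give a readable number. Going by these compounds, the true size of the step to compound 3 also stays open.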